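Compound 3: 4-phenylphenyl on the carbonyl carbon

The compounds below may be only part of what the source reports. "The series", "measured", "known", "first", "only" and "open" are said of these compounds alone.

In a functional assay on B16-F10 cells (Mus musculus) for antiproliferative activity, read by MTT assay, with a stated time of 48 h (on this read-out higher numbers stand for weaker inhibition and lower numbers for stronger inhibition), compound 1 `CCOc1ccc(C(=O)/C=C/c2c(/C=C/c3ccc(OC)cc3)cc(OC)cc2OC)cc1` gives 6.4 ug/mL and compound 2 `COc1ccc(/C=C/c2cc(OC)cc(OC)c2/C=C/C(=O)c2ccc(C)cc2C)cc1` gives 4 ug/mL. These two values lie within the scatter of each other, so the numbers do not separate compound 2 from compound 1.

Compound 3 `COc1ccc(/C=C/c2cc(OC)cc(OC)c2/C=C/C(=O)c2ccc(-c3ccccc3)cc2)cc1` has not yet been measured. It keeps the rest of compound 2 and carries 4-phenylphenyl in place of 2,4-dimethylphenyl on a carbonyl carbon.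

Going by the values given here, only one measured step bears on this change: a 1.6-fold lower number from compound 1 to compound 2 (0.20 log units; within the scatter), with 2,4-dimethylphenyl in place of 4-ethoxyphenyl on a carbonyl carbon. That step stays within the scatter, but it is a single exchange and does not involve 4-phenylphenyl, so it is only a weak guide. No step beyond the scatter is therefore expected in this assay, and no direction can be assigned with confidence. The expected step is a 1.3-fold higher number from compound 2 to compound 3 (0.10 log units; within the scatter). The range is kept wide, given the thin evidence. Compound 3 is estimated at 5 ug/mL, with an expected range of 2 ug/mL to 12 ug/mL.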

Compound 3, half-maximal inhibitory concentration: 10.6 ug/mL
Compound 3: the middle estimate sits 2.1-fold (0.33 log units) below what was measured; measured number inside the range.
By their numbers in this assay, from the lowest: compounds 2, 1 and 3 (each within the scatter of the next, the first and the last beyond it).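

Going by these compounds alone, on the carbonyl carbon, in this assay, 4-phenylphenyl in place of 2,4-dimethylphenyl gives a 2.7-fold higher number from compound 2 to compound 3 (0.42 log units; beyond the scatter): the first step beyond the scatter, showing that this position can respond to the group it carries, which the earlier pair did not show. Read against the 4-ethoxyphenyl group, the same position gives a 1.7-fold higher number from compound 1 to compound 3 (0.22 log units; within the scatter) with phenyl in place of ethoxy on an aromatic carbon, so compound 1 and compound 3 stay unseparated and the only clear difference lies between compound 2 and compound 3. No measurement at hand speaks to what lies behind this step.

Open, as far as these compounds go, is whether the higher number of compound 3 goes with the second aromatic ring of 4-phenylphenyl or with the exchange of the 2,4-dimethylphenyl group as a whole, a question on which a plain phenyl or a 4-methylphenyl group on the carbonyl carbon would bear. Also open, from the compounds shown here alone, is how an aryl group carrying an amine or a carboxylic acid would read at this position in this assay.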